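The compounds below may be only part of what the source reports. "The series", "measured", "known", "first", "only" and "open" are said of these compounds alone.

Of the compounds shown here, three of one series have been tested in a functional assay on DU-145 cells (Homo sapiens) for inhibition, read by trypan blue exclusion, with a stated time of 96 h; on this read-out lower numbers stand for stronger inhibition of growth and higher numbers for weaker inhibition of growth. Compound 1, `Cc1ccc(S/C(=C/c2sccc2C)C(=O)c2ccc(Br)cc2)cc1`, gives 50000 nM in this assay. Compound 2, `Cc1ccc(CS/C(=C/c2sccc2C)C(=O)c2ccc(Cl)cc2)cc1`, gives 10000 nM in this assay. Compound 3, `Cc1ccc(S/C(=C/c2ccc(Cl)cc2Cl)C(=O)c2ccc(Cl)cc2)cc1`, gives 10000 nM in this assay. On these numbers compound 3 stands level with compound 2, the two sharing the lowest figure of the three, while compound 1 gives a clearly higher number, beyond the usual scatter.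

The next compound, compound 4, `Cc1ccc(S/C(=C/c2sccc2C)C(=O)c2ccc(Cl)cc2)cc1`, differs from compound 3 in one place: 3-methylthiophen-2-yl in place of 2,4-dichlorophenyl on a double-bonded chain carbon bound to a double-bonded chain carbon. Among the compounds with values here, no pair of measured compounds differs in this one place alone, so the size of this step is not known from the data.

Compound 1 and compound 2 carry the same 3-methylthiophen-2-yl group and sit on either side of compound 3, which leaves the direction open. A moderate step toward a higher number is expected, a 2.0-fold higher number from compound 3 to compound 4 (0.30 log units; within the scatter). For compound 4 the estimate in this assay is 20000 nM, with a range from 5000 nM to 60000 nM.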

Compound 4, concentration for 50% growth inhibition: 50000 nM
Compound 4: the middle estimate sits 2.5-fold (0.40 log units) below what was measured; low and high end bracket the measured number.
By their numbers in this assay, from the lowest: compounds 2 and 3 (each within the scatter of the next); then compounds 1 and 4 (each within the scatter of the next).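

In this assay, 3-methylthiophen-2-yl in place of 2,4-dichlorophenyl on a double-bonded chain carbon bound to a double-bonded chain carbon gives a 5.0-fold higher number from compound 3 to compound 4 (0.70 log units; beyond the scatter), so the group at this position affects growth inhibition. The group on sulfur counts as well: 4-methylphenyl in place of 4-methylbenzyl on a sulfur gives a 5.0-fold higher number from compound 2 to compound 4 (0.70 log units; beyond the scatter), with the 3-methylthiophen-2-yl group present in both compounds. By contrast, chloro in place of bromo on an aromatic carbon gives no change at the digits printed from compound 1 to compound 4 (within the scatter), so this exchange of halogens leaves the read-out unmoved.

As far as these compounds go, how an amine or a carboxylic acid on a phenyl ring at the double-bonded chain carbon would compare with these two groups remains open. The data offer no explanation for the size of any of these steps.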